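Cyclobutyl to cyclohexyl: one step in the series

The compounds below may be only part of what the source reports. "The series", "measured", "known", "first", "only" and "open" are said of these compounds alone.

Measured compounds:
compound 1 `O=c1cc(-c2ccccc2)oc2ccc(OCCCCCCN3CCCCC3)cc12`: 101 nM
compound 2 `COc1ccc(-c2cc(=O)c3cc(OCCCCCN4CCC(O)CC4)ccc3o2)cc1`: 493 nM
compound 3 `O=c1cc(C2CCC2)oc2ccc(OCCCCCCN3CCCCC3)cc12`: 51 nM

In an assay on isolated protein (Cavia porcellus) with Sigma non-opioid intracellular receptor 1 (Homo sapiens) as the target, read by radioligand binding (a higher number here means a weaker inhibitor, a lower number a stronger inhibitor), compound 3 gives 51 nM, the lowest of the three numbers; compound 1 gives 101 nM, and compound 2 gives 493 nM. Compound 4 `O=c1cc(C2CCCCC2)oc2ccc(OCCCCCCN3CCCCC3)cc12` is not yet measured. It differs from compound 3 in one place: cyclohexyl in place of cyclobutyl on an aromatic carbon. Within the data shown here, the only measured step at this carbon is a 2.0-fold lower number from compound 1 to compound 3 (0.30 log units; within the scatter); compound 2 differs from the others in more than one place and yields no step. Phenyl and cyclobutyl at this carbon thus sit within the scatter of each other, so the exchange for the six-membered ring is expected to give a 1.1-fold lower number from compound 3 to compound 4 (0.05 log units; within the scatter), not beyond the scatter in either direction. For compound 4 the estimate is 45 nM, with a range from 15 nM to 150 nM.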

Compound 4, half-maximal inhibitory concentration: 55 nM
Beside the measured number, compound 4's estimate is 1.2-fold (0.09 log units) below it, within the range that was stated.
By their numbers in this assay, from the lowest: compounds 3, 4 and 1 (each within the scatter of the next); then compound 2.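

At the aromatic carbon next to the ring oxygen, this assay gives a 1.1-fold higher number from compound 3 to compound 4 (0.03 log units; within the scatter), so the larger non-aromatic ring brings no change beyond the scatter. The exchange against the aromatic ring gives a 1.8-fold lower number from compound 1 to compound 4 (0.26 log units; within the scatter), which places phenyl, cyclobutyl and cyclohexyl at this carbon within the scatter of one another on the shared core of compounds 1, 3 and 4. Nothing at hand gives a reason for this flat result. Still open, on these data alone, is whether a group other than these carbon rings, such as an amine, a carboxylic acid or a methyl, would stay within the scatter at this carbon.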